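Dropping the Chloro Group from Compound 2

The compounds below may be only part of what the source reports. "The series", "measured", "known", "first", "only" and "open" are said of these compounds alone.

Compound 1, `C/C=C/C(=O)N(Cc1ccc(OC)c([N+](=O)[O-])c1)c1cc(OC)c(OC)c(OC)c1`: 670 nM
Compound 2, `C/C=C/C(=O)N(Cc1ccc(OC)c(Cl)c1)c1cc(OC)c(OC)c(OC)c1`: 1420 nM

Both were measured in a functional assay on HCT-116 cells (Homo sapiens) for inhibition, read by MTT assay, with a stated time of 48 h; on this read-out lower numbers stand for stronger inhibition and higher numbers for weaker inhibition. Going by the values given here, compound 2 gives the higher of the two numbers, and the only known step, a 2.1-fold higher number from compound 1 to compound 2 (0.33 log units; beyond the scatter), separates it from compound 1. Compound 3, `C/C=C/C(=O)N(Cc1ccc(OC)cc1)c1cc(OC)c(OC)c(OC)c1`, differs from compound 2 by hydrogen in place of chloro on an aromatic carbon. That single measured step concerns a different group entering the same position, so it offers only loose guidance here. A small rise in the number, or none beyond the scatter, is expected, namely a 1.3-fold higher number from compound 2 to compound 3 (0.13 log units; within the scatter). Compound 3 is therefore estimated at 1900 nM, with a range from 750 nM to 4800 nM.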

Compound 3, half-maximal inhibitory concentration: 500 nM
Estimate against measurement, compound 3: 3.8-fold (0.58 log units) above; the whole stated range lies above it.
By their numbers in this assay, from the lowest: compounds 3 and 1 (each within the scatter of the next); then compound 2.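

Taking the chloro group away gives a 2.8-fold lower number from compound 2 to compound 3 (0.45 log units; beyond the scatter), so this position needs no substituent for inhibition at this level: the 4-methoxyphenyl compound inhibits more strongly than its 3-chloro-4-methoxyphenyl counterpart. Hydrogen and nitro cannot be told apart here, with a 1.3-fold lower number from compound 1 to compound 3 (0.13 log units; within the scatter), so among these three groups only chloro stands apart. No measurement at hand explains why compound 2 inhibits less strongly than compound 3. Going by these compounds, what fluorine, a hydroxyl group or an amine would give at this position remains open. Three groups are too few to set a rule for it.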